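Swapping an Open-Chain Amine for a Phenylpyrrolidine

The source may hold more compounds than are shown below. What is called first, only, known or untested is meant among the compounds shown, and "the series" means these compounds.

Of the compounds shown here, three built on one shared core have been tested in an assay on cells for displacement of a labelled ligand from corticotropin-releasing factor receptor 1 (Homo sapiens), with a stated time of 100 min; on this read-out higher numbers stand for weaker inhibition and lower numbers for stronger inhibition. Compound 1 `CCCN(CC1CC1)C(=O)c1c(C)nc2n(-c3c(C)cc(C)cc3C)c(Cl)cn12` gives 61 nM, compound 2 `CCCCN(CC)Cc1c(C(F)(F)F)nc2n(-c3c(C)cc(C)cc3C)c(Cl)cn12` gives 78 nM, and compound 3 `Cc1cc(C)c(-n2c(Cl)cn3c(CN(CCC(F)(F)F)Cc4ccc(Cl)cc4)c(C(F)(F)F)nc23)c(C)c1` gives 12 nM. Compound 2 thus carries the highest number of the three: its gap to compound 1 lies within the scatter, while compound 3 sits clearly lower, beyond it. Compound 4 `Cc1cc(C)c(-n2c(Cl)cn3c(CN4CCC(c5ccccc5)C4)c(C(F)(F)F)nc23)c(C)c1` has not yet been measured. It differs from compound 2 in one place: 3-phenylpyrrolidin-1-yl in place of butyl(ethyl)amino on a saturated chain carbon bound to an aromatic carbon. Because compound 3, which also bears a larger group carrying an aromatic ring at that position, gives 12 nM, a modest downward step beyond the scatter is expected for compound 4 a 2.6-fold lower number from compound 2 to compound 4 (0.41 log units; beyond the scatter). Compound 4 is therefore estimated at 30 nM, with a range from 8 nM to 120 nM.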

Compound 4, inhibition constant: 610 nM
Estimate against measurement, compound 4: 20-fold (1.31 log units) below, and the stated range ends below it.
By their numbers in this assay, from the lowest: compound 3; then compounds 1 and 2 (each within the scatter of the next); then compound 4.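

In this assay, putting 3-phenylpyrrolidin-1-yl in place of butyl(ethyl)amino on this saturated chain carbon gives a 7.8-fold higher number from compound 2 to compound 4 (0.89 log units; beyond the scatter), so the position clearly responds to the choice of amine. Compound 3 also has an aromatic ring on its amine and gives 12 nM, while compound 4 gives 610 nM, so an aromatic ring there does not alone decide the number. No measurement shown here explains this step.

As far as these compounds go, it remains open whether the higher number comes with the closed ring or with the phenyl. A plain pyrrolidine without the phenyl at this place would help separate the two.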